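Swapping one hydroxyphenyl group on compound 2

This account rests on a few compounds, and the source may have more. Where it says the series, first, only, none or still open, it means among the compounds named here.

In an ADME assay on PC-12 cells (Rattus norvegicus) for cytotoxicity, read by WST assay, with a stated time of 24 h (a lower number here means that less compound is tolerated, a higher number that more compound is tolerated), compound 1 `O=C(/C=C/c1ccccc1O)CC(=O)/C=C/c1cc(O)ccc1O` gives 38000 nM and compound 2 `O=C(/C=C/c1ccccc1O)/C=C/c1cccc(O)c1O` gives 54000 nM. These two values lie within the usual scatter of each other, so compound 2 does not stand apart from compound 1. Compound 3 `O=C(/C=C/c1ccc(O)cc1)/C=C/c1cccc(O)c1O` has 4-hydroxyphenyl in place of the 2-hydroxyphenyl of compound 2 on a double-bonded chain carbon bound to a double-bonded chain carbon (4-hydroxyphenyl in place of 2-hydroxyphenyl on a double-bonded chain carbon bound to a double-bonded chain carbon). Among the compounds with values here, no measured pair shows this change, so the expectation rests on compound 2 at 54000 nM, with no step beyond the scatter expected in this assay. The estimated change is a 1.2-fold lower number from compound 2 to compound 3 (0.08 log units; within the scatter). For compound 3 the estimated value is 45000 nM, with an expected range of 20000 nM to 100000 nM.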

Compound 3, half-maximal cytotoxic concentration in the PC-12 assay: 12000 nM
Compound 3: middle estimate off by 3.8-fold (0.57 log units), on the high side, and the stated range ends above it.
By their numbers in the PC-12 assay, from the lowest: compound 3; then compounds 1 and 2 (each within the scatter of the next).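

In the PC-12 assay compound 2 gives 54000 nM and compound 3 gives 12000 nM and 4-hydroxyphenyl in place of 2-hydroxyphenyl gives a 4.5-fold lower number from compound 2 to compound 3 (0.65 log units; beyond the scatter) at this place on the chain, so the same atoms joined differently are enough to separate two compounds. In a physicochemical assay for solubility, using the shake flask method, with a stated time of 12 h (on this read-out higher numbers stand for higher solubility and lower numbers for lower solubility), compound 2 gives 151000 nM and compound 3 gives 120000 nM and the same swap gives a 1.3-fold lower number from compound 2 to compound 3 (0.10 log units; within the scatter) so only the cell read-out tells compound 2 and compound 3 apart. Nothing shown here gives a reason for this difference. Still open, as far as these compounds go, is how the cell read-out and solubility would respond to a different group at this place, such as a methoxyphenyl group or a carboxylic acid.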